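The source may hold more compounds than are shown below. What is called first, only, known or untested is meant among the compounds shown, and "the series" means these compounds.

Three compounds of the shared core have numbers in a functional assay on LOX IMVI cells (Homo sapiens) for inhibition, read by sulforhodamine B assay, with a stated time of 48 h; on this read-out higher numbers stand for weaker inhibition of growth and lower numbers for stronger inhibition of growth. Compound 1 `Nc1cc(N)c2nc(-c3ccccc3)c(NCc3ccc(Cl)c(Cl)c3)nc2c1` gives 2140 nM. Compound 2 `COc1cc(CNc2nc3cc(N)cc(N)c3nc2-c2ccccc2)cc(OC)c1OC` gives 3160 nM, which lies within the scatter of compound 1. Compound 3 `CCOC(=O)[C@H](CCC(=O)O)NC(=O)c1ccc(Oc2nc3cc(N)cc(N)c3nc2-c2ccccc2)cc1` gives 12000 nM, a weaker inhibition of growth that lies beyond the scatter. Compound 1 thus has the lowest number of the three, though it cannot be set apart from compound 2. Compound 4 `Nc1cc(N)c2nc(-c3ccccc3)c(NCc3ccc(F)cc3)nc2c1` is not yet measured; it differs from compound 1 by 4-fluorophenyl in place of 3,4-dichlorophenyl on a saturated chain carbon bound to a nitrogen on an aromatic ring. Within the data shown here, no measured pair isolates this change, so its size rests on expectation alone. A modest weakening is expected, the step estimated at a 1.5-fold higher number from compound 1 to compound 4 (0.17 log units; within the scatter). Compound 4 is therefore expected to give 3200 nM, in the range 1300 nM to 8000 nM.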

Compound 4, concentration for 50% growth inhibition: 1510 nM
Compound 4: the middle estimate sits 2.1-fold (0.33 log units) above what was measured; the measured number falls inside the stated range.
By their numbers in this assay, from the lowest: compounds 4, 1 and 2 (each within the scatter of the next, the first and the last beyond it); then compound 3.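

In this assay, the first step read at this position is a 1.4-fold lower number from compound 1 to compound 4 (0.15 log units; within the scatter), for 4-fluorophenyl in place of 3,4-dichlorophenyl on a saturated chain carbon bound to a nitrogen on an aromatic ring. This position therefore accepts the exchange of both chlorines for one fluorine without a shift beyond the scatter. No measurement on these compounds accounts for this.

Going by these compounds, it remains open how a plain benzyl, or a benzyl carrying a carboxylic acid or an amine, would read here. A longer chain at this position is equally untested in the compounds shown.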